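Ring-size swap on the longer chain, anilide series

A few compounds are considered here, and "the series" means these few. Any claim that something is new, unique, unknown or untested is made for them only; others in the source may bear on it.

Four cinnamanilides sharing one core, differing in the basic amine and in the chain that carries it. Compound 1 `COc1cc(/C=C/C(=O)Nc2ccccc2)ccc1OCCCCN1CCCCC1` gives 1.61 in a physicochemical assay for lipophilicity, using the shake flask method, measured as octanol-water partition, at pH 7.4; a lower number here means a more polar compound, a higher number a more lipophilic compound. Compound 2 `COc1cc(/C=C/C(=O)Nc2ccccc2)ccc1OCCCCN1CCCC1` gives 1.6; the step of a number 0.01 log units lower from compound 1 to compound 2 (within the scatter) goes with pyrrolidin-1-yl in place of piperidin-1-yl on a saturated chain carbon, four bonds along the chain from an oxygen on an aromatic ring. Compound 3 `COc1cc(/C=C/C(=O)Nc2ccccc2)ccc1OCCCCCCN1CCCCC1` gives 1.77; the step of a number 0.16 log units higher from compound 1 to compound 3 (within the scatter) goes with 2-(piperidin-1-yl)ethyl in place of piperidin-1-yl on a saturated chain carbon, four bonds along the chain from an oxygen on an aromatic ring, and a number 0.17 log units higher from compound 2 to compound 3 (within the scatter) connects compound 2 to compound 3. All three numbers sit inside the usual scatter of one another.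

Compound 4 `COc1cc(/C=C/C(=O)Nc2ccccc2)ccc1OCCCCCCN1CCCC1` is not yet measured. It differs from compound 3 by pyrrolidin-1-yl in place of piperidin-1-yl on a saturated chain carbon, six bonds along the chain from an oxygen on an aromatic ring. This is the same kind of change as from compound 1 to compound 2, but not the same: there the place is four bonds along the chain from the oxygen on the aromatic ring, here six bonds along the chain. The cores of the two pairs differ by 2-(piperidin-1-yl)ethyl in place of piperidin-1-yl on a saturated chain carbon, four bonds along the chain from an oxygen on an aromatic ring.

The expected step of a number 0.01 log units lower from compound 3 to compound 4 (within the scatter) for compound 4 rests on compound 1 to compound 2 giving a number 0.01 log units lower from compound 1 to compound 2 (within the scatter). Compound 4 is thus estimated at 1.76, with a range of 1.5 to 2.02.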

Compound 4, partition coefficient: 1.76
Compound 4: middle estimate and measured number agree at the digits printed; the range from low to high includes it.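

In this assay, pyrrolidin-1-yl in place of piperidin-1-yl, six bonds along the chain from the oxygen on the aromatic ring, gives a number 0.01 log units lower from compound 3 to compound 4 (within the scatter), and the same swap four bonds along the chain gives a number 0.01 log units lower from compound 1 to compound 2 (within the scatter), so in both cores shown the step lies within the scatter. The steps of a number 0.16 log units higher from compound 2 to compound 4 (within the scatter) and a number 0.15 log units higher from compound 1 to compound 4 (within the scatter) are also within the scatter, as are all the other steps among the four compounds, so the series shows that a step within the scatter carried over between two cores, not that a step of real size would carry over, nor that the two amines are equivalent in general. No measurement is available that would explain these numbers.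

The compounds shown leave open whether the swap stays this small on a longer chain. They also leave open what this assay would read with a morpholine or a dimethylamine in place of these two rings.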